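A few compounds are considered here, and "the series" means these few. Any claim that something is new, unique, unknown or untested is made for them only; others in the source may bear on it.

Measured in a functional assay on MCF7 cells (Homo sapiens) for antiproliferative activity, read by MTT assay, with a stated time of 72 h; on this read-out higher numbers stand for weaker inhibition and lower numbers for stronger inhibition:
- compound 1 `COc1ccc(/C=C2/CN(C)/C(=N/c3ccc(C)cc3)S2)cc1`: 7600 nM
- compound 2 `COc1ccc(/C=C2\S/C(=N\c3ccc(Cl)cc3)N(C)C2=O)cc1`: 39300 nM
- compound 3 `S=C(Nc1ccccc1)N1C/C(=C/c2ccccc2)S/C1=N\c1ccccc1`: > 100000 nM

Of the compounds shown here, three have been tested for antiproliferative activity in this assay. Compound 3 gives > 100000 nM, and this is a limit of the assay rather than a number. That leaves two numerical values. Compound 1 gives 7600 nM and compound 2 gives 39300 nM, so compound 2 holds the higher of the two, with weaker inhibition by a margin beyond the scatter.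

The next compound to be measured is compound 4 `COc1ccc(/C=C2\S/C(=N\c3ccc(F)cc3)N(C)C2=O)cc1`. Its difference from compound 2 is fluoro in place of chloro on an aromatic carbon, para to a large group. Within the data shown here, no measured pair of compounds shows this change, so the expectation rests on the small size of the exchange alone. In this assay the expected step is a 1.3-fold lower number from compound 2 to compound 4 (0.12 log units; within the scatter), and no change beyond the scatter is expected in either direction. The estimated value for compound 4 is 30000 nM, with an expected range of 10000 nM to 85000 nM.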

Compound 4, half-maximal inhibitory concentration: 66500 nM
Compound 4: the middle estimate sits 2.2-fold (0.35 log units) below what was measured; measured number inside the range.
By their numbers in this assay, from the lowest: compound 1; then compounds 2 and 4 (each within the scatter of the next). At a limit, above all of these: compound 3.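

Going from 4-chlorophenyl to 4-fluorophenyl in this assay gives a 1.7-fold higher number from compound 2 to compound 4 (0.23 log units; within the scatter). Among these compounds, this is the first pair in the set that differs in one place only, and it shows that, on this read-out, chloro and fluoro cannot be told apart at this position on the aromatic ring of the shared core. Nothing measured among these compounds offers a reason for this result.

On these data alone, what this position accepts beyond these two groups stays open: an amine, a carboxylic acid or a nitrile on the same aromatic carbon could give quite a different number. Also open, as far as these compounds go, is whether the exchange of chloro for fluoro would read the same on the core of compound 1 or in another cell line.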